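A few compounds are considered here, and "the series" means these few. Any claim that something is new, unique, unknown or untested is made for them only; others in the source may bear on it.

Compound 1 `CCCCCC/C=C/C[C@H]1C[C@@H]([C@@H](O)c2ccccc2)CO[C@@H]1c1ccccc1`: 4990 nM
Compound 2 `C=CC[C@H]1C[C@@H]([C@@H](O)c2ccccc2)CO[C@@H]1c1ccccc1`: 36000 nM
Compound 3 `Cc1ccc(/C=C/C[C@H]2C[C@@H]([C@@H](O)c3ccccc3)CO[C@@H]2c2ccccc2)cc1C`: 9880 nM

These values come from a functional assay on HL-60 cells (Homo sapiens) for cytotoxicity, read by WST assay, with a stated time of 48 h; a higher number here means a weaker inhibitor, a lower number a stronger inhibitor. Compound 3, at 9880 nM, cannot be told apart from compound 1, given a 2.0-fold higher number from compound 1 to compound 3 (0.30 log units; within the scatter). The gap to compound 2 is real, with a 3.6-fold lower number from compound 2 to compound 3 (0.56 log units; beyond the scatter).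

Compound 4 `O[C@@H](c1ccccc1)[C@H]1CO[C@H](c2ccccc2)[C@@H](C/C=C/c2ccc(F)cc2)C1` keeps the shared core and differs from compound 3 in one place, on a double-bonded chain carbon bound to a double-bonded chain carbon: 4-fluorophenyl in place of 3,4-dimethylphenyl on a double-bonded chain carbon bound to a double-bonded chain carbon.

Among the compounds with values here, no measured step exchanges one aromatic group for another, so the evidence here is indirect. Exchanging hexyl for 3,4-dimethylphenyl gave a 2.0-fold higher number from compound 1 to compound 3 (0.30 log units; within the scatter), which shows that two quite different end groups can give values within the scatter of each other. The clear change appears only with the vinyl group of compound 2, at a 7.2-fold higher number from compound 1 to compound 2 (0.86 log units; beyond the scatter). Compound 4 keeps an aromatic end group, as compound 3 does, so no step beyond the scatter is expected in this assay. Within the data shown here, no fluorinated compound has been measured yet, which leaves the range fairly wide.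

The expected change is small, a 1.1-fold higher number from compound 3 to compound 4 (0.05 log units; within the scatter).

For compound 4 the estimated value is 11000 nM, with an expected range of 5000 nM to 25000 nM.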

Compound 4, half-maximal inhibitory concentration: 8110 nM
Compound 4: the middle estimate sits 1.4-fold (0.13 log units) above what was measured, within the range that was stated.
By their numbers in this assay, from the lowest: compounds 1, 4 and 3 (each within the scatter of the next); then compound 2.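

In this assay, within the data shown here, the exchange of 3,4-dimethylphenyl for 4-fluorophenyl on a double-bonded chain carbon bound to a double-bonded chain carbon stays within the scatter (a 1.2-fold lower number from compound 3 to compound 4 (0.09 log units; within the scatter)), and this is the first direct exchange of one aromatic end group for another at this position. The replacement of hexyl by 4-fluorophenyl also stays within the scatter (a 1.6-fold higher number from compound 1 to compound 4 (0.21 log units; within the scatter)), whereas the step from the short vinyl group to 2-(4-fluorophenyl)ethenyl lies beyond it (a 4.4-fold lower number from compound 2 to compound 4 (0.65 log units; beyond the scatter)), so a fluorine-bearing end group joins the two larger end groups already seen, and among the four compounds only the vinyl one stands apart. Nothing measured here explains why these end groups give such similar values.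

Still open, on these data alone, is whether this tolerance holds for end groups of a different kind, such as a 4-aminophenyl ring, a benzoic acid or a chain longer than hexyl. A single aromatic fluorine also says little about what a trifluoromethyl or methoxy group on the same ring would do.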